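Swapping the group on the sulfonyl oxygen of compound 3

This account rests on a few compounds, and the source may have more. Where it says the series, first, only, none or still open, it means among the compounds named here.

Among the measured compounds shown here, in a functional assay on MCF7 cells (Homo sapiens) for antiproliferative activity, read by sulforhodamine B assay, with a stated time of 48 h (on this read-out higher numbers stand for weaker inhibition and lower numbers for stronger inhibition), compound 1 (`Cc1ccccc1OS(=O)(=O)c1ccc(N2CCN(C)C2=O)cc1`) gives 5600 nM and is the only compound here with a true number. Compound 2 (`CCN1CCN(c2ccc(S(=O)(=O)Oc3ccc(OC)cc3)cc2)C1=O`) gives > 100000 nM as a limit of the assay. Compound 3 (`CCCN1CCN(c2ccc(S(=O)(=O)Oc3ccccc3C)cc2)C1=O`) gives > 100000 nM and this too is a limit, not a number.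

Compound 4 (`CCCN1CCN(c2ccc(S(=O)(=O)Oc3cc(Cl)c(Cl)cc3Cl)cc2)C1=O`) is still unmeasured. It carries 2,4,5-trichlorophenyl in place of 2-methylphenyl on the oxygen bound to the sulfonyl sulfur (2,4,5-trichlorophenyl in place of 2-methylphenyl on an oxygen).

For the measured compounds named here, the one measured step is an at least 17-fold higher number from compound 1 to compound 3 (1.25 log units; beyond the scatter) and it is large. It lies on a saturated chain carbon bound to an amide-type nitrogen in a ring, not on that oxygen, so it is only an indirect guide. It does show that one small change can separate a number from a limit in this assay here.

A modest move toward stronger inhibition is expected, estimated as an at least 3.3-fold lower number from compound 3 to compound 4 (0.52 log units; beyond the scatter) with wide uncertainty. Compound 4 is expected at an estimated 30000 nM with a range from 4000 nM to 100000 nM in this assay and it may well report only a limit.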

Compound 4, half-maximal inhibitory concentration: 13000 nM
For compound 4 the middle estimate is 2.3-fold (0.36 log units) above the measured one; measured number inside the range.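

The group on the oxygen bound to the sulfonyl sulfur matters in its own right: with everything else in the molecule unchanged, 2,4,5-trichlorophenyl in place of 2-methylphenyl gives an at least 7.6-fold lower number from compound 3 to compound 4 (0.88 log units; beyond the scatter). The earlier step, an at least 17-fold higher number from compound 1 to compound 3 (1.25 log units; beyond the scatter), might have suggested that the chain of compound 3 ends measurable activity, yet compound 4 carries that same chain and still gives a true number. Compound 3 stands at a limit of the assay and not at a number, so this new step gives only a minimum size: the limit of > 100000 nM in this assay, at which 2 of the 4 values shown sit.

The compounds shown do not tell whether all three chlorines are needed, or whether a single chlorine or a trifluoromethyl group on the phenyl ring would do as well. Going by these compounds, it also stays open whether 2,4,5-trichlorophenyl would lower the number on the core of compound 1.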